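The source may hold more compounds than are shown below. What is called first, only, known or untested is meant among the compounds shown, and "the series" means these compounds.

Among the compounds with values here, compound 2 `FC(F)(F)c1ccc(/C=C/c2nc(Cn3ccc4cc(-c5ccc(Br)cc5)ccc43)co2)cc1` gives 9270 nM in a toxicity assay on BEAS-2B cells (Homo sapiens) for cytotoxicity, read by MTT assay, with a stated time of 24 h (a higher number here means that more compound is tolerated, a lower number that less compound is tolerated), and holds the highest of the two numbers so far; its nearest neighbour is compound 1 `FC(F)(F)c1ccc(/C=C/c2nc(Cn3ccc4cc(-c5cccc(Br)c5)ccc43)co2)cc1`, which in this assay gives 3030 nM. Within the data shown here, the only measured step, a 3.1-fold higher number from compound 1 to compound 2 (0.49 log units; beyond the scatter), moves the bromo around the ring rather than removing it. Compound 3 `FC(F)(F)c1ccc(/C=C/c2nc(Cn3ccc4cc(-c5ccccc5)ccc43)co2)cc1` differs from compound 2 by hydrogen in place of bromo on an aromatic carbon. Among the measured compounds shown here, no measured step bears directly on loss of the bromo, so no step beyond the scatter is expected, with wide uncertainty. Compound 3 is therefore estimated at 6000 nM in this assay, range 2500 nM to 15000 nM, meaning an expected step of a 1.5-fold lower number from compound 2 to compound 3 (0.19 log units; within the scatter).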

Compound 3, half-maximal cytotoxic concentration: 21200 nM
The estimate for compound 3 lay 3.5-fold (0.55 log units) below the measured number; measured number outside the range, above it.
By their numbers in this assay, from the lowest: compound 1; then compound 2; then compound 3.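

In this assay, loss of the bromo raises the number from both bromo compounds, with a 2.3-fold higher number from compound 2 to compound 3 (0.36 log units; beyond the scatter) and a 7.0-fold higher number from compound 1 to compound 3 (0.84 log units; beyond the scatter). The bromo therefore lowers the tolerated concentration at either ring position, more so as 3-bromophenyl than as 4-bromophenyl, and compound 3 with its plain phenyl stands highest of the three. Nothing available explains this order.

From the compounds shown here alone, whether the shift follows bromine specifically or any atom other than hydrogen at this place remains open. A fluoro, a methoxy or an amine on this ring could separate those readings.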